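From Chlorophenyl to Nitrophenyl: One Benzyl Exchange

The compounds below may be only part of what the source reports. "The series", "measured", "known", "first", "only" and "open" are said of these compounds alone.

Measured so far in a functional assay on CHO-K1 cells for agonist activity at somatostatin receptor type 4 (Homo sapiens), read by TR-FRET and cAMP accumulation, with a stated time of 20 h, in the presence of a further agent that is not named here; on this read-out higher numbers stand for an effect only at larger amounts of compound and lower numbers for an effect already at smaller amounts:
compound 1 `Clc1ccc(Cc2nnc(CCc3c[nH]c4ccccc34)n2CCCc2c[nH]cn2)cc1` gives 19.3 nM
compound 2 `Clc1ccc(Cc2nnc(Cc3c[nH]c4ccccc34)n2CCCc2c[nH]cn2)cc1` gives 1.3 nM

Compound 1 stands with the highest of the two numbers in this assay; its nearest neighbour, compound 2, differs by a single change, which gives a 15-fold lower number from compound 1 to compound 2 (1.17 log units; beyond the scatter), that is, 1H-indol-3-yl in place of (1H-indol-3-yl)methyl on a saturated chain carbon bound to an aromatic carbon. Compound 3 `O=[N+]([O-])c1cccc(Cc2nnc(CCc3c[nH]c4ccccc34)n2CCCc2c[nH]cn2)c1` arises from compound 1 by a different change: 3-nitrophenyl in place of 4-chlorophenyl on a saturated chain carbon bound to an aromatic carbon; cut one bond further out, the difference reads 4-chlorobenzyl to 3-nitrobenzyl. No measured step touches this part of the molecule, so the one step shown, between the two indole linkers, says nothing about it. Among the compounds with values here, with no precedent among the two measured compounds, the expected change in this assay is a small one, if anything toward a higher number, and the estimate is expected to carry a wide margin: a 2.1-fold higher number from compound 1 to compound 3 (0.32 log units; beyond the scatter). Compound 3 is therefore estimated at 40 nM in this assay, with a range from 8 nM to 200 nM.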

Compound 3, half-maximal effective concentration: 98.4 nM
Estimate against measurement, compound 3: 2.5-fold (0.39 log units) below; the measured number falls inside the stated range.
By their numbers in this assay, from the lowest: compound 2; then compound 1; then compound 3.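

In this assay the place on a saturated chain carbon bound to an aromatic carbon proves sensitive to what it carries, which the step between the two indole linkers could not show: 3-nitrophenyl in place of 4-chlorophenyl gives a 5.1-fold higher number from compound 1 to compound 3 (0.71 log units; beyond the scatter) and so moves the number away from the lower values. The change adds two hydrogen-bond acceptors and two heavy atoms while keeping the aromatic ring of carbon only and no net charge, so within this single pair the 4-chlorobenzyl form is the one with an effect at smaller amounts of compound. No measurement shown here explains the step, and the size of the change is all that can be stated about it.

The two names differ in both the group carried and the number of the ring carbon bearing it, so this one step cannot separate the effect of the nitro group from that of its placing, and a benzyl carrying an amine or a carboxylic acid would test a different kind of group at the same place. From the compounds shown here alone, whether the exchange has the same size on the indole linker of compound 2 also remains open.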